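A Carbamate on the Aromatic Oxygen of a Prenylated Core

This account rests on a few compounds, and the source may have more. Where it says the series, first, only, none or still open, it means among the compounds named here.

Compound 1 `CC(C)=CCC1Cc2c(O)cc(=O)n(CCCO)c2CC1(C)C` gives 25.6% in a functional assay on PANC-1 cells (Homo sapiens) for inhibition, read by MTT assay, with a stated time of 24 h, tested at 10 uM; on this read-out higher numbers stand for more inhibition at the one concentration tested (going by the name of the read-out) and lower numbers for less inhibition. Compound 2 `CC(C)=CCC/C(C)=C/CC1Cc2c(O)cc(=O)n(CCCO)c2CC1(C)C` gives 28.7% in this assay, and compound 3 `COc1ccccc1NC(=O)Oc1cc(=O)n(CCCO)c2c1CC(CC=C(C)C)C(C)(C)C2` gives 71.1%. Among the three measured numbers compound 2 stands second highest; its nearest neighbour is compound 1, a number 3.1 percentage points higher from compound 1 to compound 2 (within the scatter), while compound 3 lies far above it.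

Compound 4 `COc1cccc(NC(=O)Oc2cc(=O)n(CCCO)c3c2CC(C/C=C(\C)CCC=C(C)C)C(C)(C)C3)c1` has not yet been measured. It differs from compound 2 by (3-methoxyphenyl)carbamoyl in place of hydrogen on an oxygen on an aromatic ring, so that the hydroxy of compound 2 becomes a ((3-methoxyphenyl)carbamoyl)oxy group. Going by the values given here, the one measured step that bears on this is a number 45.5 percentage points higher from compound 1 to compound 3 (beyond the scatter), where a closely related carbamoyl group replaced hydrogen on the same oxygen. The step from compound 1 to compound 2 showed that the longer chain itself moves the number little. A large rise is therefore expected for compound 4, a number 41.3 percentage points higher from compound 2 to compound 4 (beyond the scatter). Compound 4 is accordingly expected to give about 70%, within a range from 52% to 85%.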

Compound 4, a percentage reported as inhibition, at one concentration (the size of the read-out at that concentration, not a potency): 47%
The estimate for compound 4 lay 23 percentage points above the measured number; the measured number lies below the stated range.
By their numbers in this assay, from the lowest: compounds 1 and 2 (each within the scatter of the next); then compound 4; then compound 3.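

The carbamoyl change on this oxygen raises the number on the longer-chain compound as well, a number 18.3 percentage points higher from compound 2 to compound 4 (beyond the scatter), so the response at this position is not confined to the shorter chain of compound 1. This step is nevertheless smaller than the earlier one, a number 45.5 percentage points higher from compound 1 to compound 3 (beyond the scatter), which means that a carbamoyl group at this oxygen does not bring a rise of one fixed size. Nothing at hand accounts for the smaller rise.

Compound 3 and compound 4 differ in both the chain and the carbamoyl group, so the compounds shown cannot separate the contribution of the 3-methylbut-2-en-1-yl extension from that of the (3-methoxyphenyl)carbamoyl group. They also leave open how a plain phenylcarbamoyl or an acetyl group on the same oxygen would read.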